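A few compounds are considered here, and "the series" means these few. Any claim that something is new, unique, unknown or untested is made for them only; others in the source may bear on it.

Working notes on the series. Compound 1 `Cc1c(-c2ccccc2)sc(N)c1C(=O)c1ccc(Cl)cc1`, compound 2 `CC(C)(C)Cc1c(-c2ccc(F)cc2)sc(N)c1C(=O)c1ccc(Cl)cc1` and compound 3 `COCCOc1ccc(-c2sc(N)c(C(=O)c3ccc(Cl)cc3)c2CC(C)(C)C)cc1` share one core and differ only in the group carried on the aromatic carbon next to the ring sulfur. In an assay on CHO cells for displacement of a labelled ligand from adenosine receptor A3 (Homo sapiens), read by scintillation counting, tested at 10 uM (a lower number here means less inhibition, a higher number more inhibition at the concentration tested (going by the name of the read-out)), compound 1 gives 1%, compound 2 gives 9% and compound 3 gives 1%; the three numbers lie within the scatter of one another, so compound 2 is not set apart from the other two on these data. For the measured compounds named here, the single step between measured neighbours, a number 8 percentage points lower from compound 2 to compound 3 (within the scatter), came with 2-methoxyethoxy in place of fluoro on an aromatic carbon and moved nothing beyond the scatter.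

Compound 4 `CC(C)(C)Cc1c(-c2ccsc2)sc(N)c1C(=O)c1ccc(Cl)cc1` is not yet measured. Against compound 2 the change is thiophen-3-yl in place of 4-fluorophenyl on an aromatic carbon. Going by the values given here, no measured step matches this exchange; the only step touching that aromatic carbon stayed within the scatter, so in this assay no step beyond the scatter is expected in either direction. Compound 4 is expected to give 5%, with a range from 0% to 15%. This estimate means an expected step of a number 4 percentage points lower from compound 2 to compound 4 (within the scatter).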

Compound 4, a percentage reported as inhibition, at one concentration (the size of the read-out at that concentration, not a potency): 4%
Beside the measured number, compound 4's estimate is 1 percentage points above it, within the range that was stated.
By their numbers in this assay, from the lowest: compounds 1, 3, 4 and 2 (each within the scatter of the next).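

Thiophen-3-yl in place of 4-fluorophenyl gives a number 5 percentage points lower from compound 2 to compound 4 (within the scatter). The earlier step changed only a group on the aromatic ring at this carbon, whereas this one replaces the ring itself: a six-membered aromatic ring of carbon only gives way to a five-membered aromatic ring with 1 hetero atom, and this assay still shows no step beyond the scatter. No measurement at hand bears on what lies behind this result.

The compounds shown carry only aromatic rings on the aromatic carbon next to the ring sulfur, so the response to a saturated ring such as piperidine, or to a carboxylic acid or an amine on the aromatic ring, remains open. As far as these compounds go, whether any group here can move the number beyond the scatter also remains open.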